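Replacing the Aryl Group of Compound 3

The compounds below may be only part of what the source reports. "The series", "measured", "known", "first", "only" and "open" are said of these compounds alone.

Of the compounds shown here, three built on a shared core have been tested in a functional assay on PC-3 cells (Homo sapiens) for inhibition, read by MTT assay, with a stated time of 48 h, tested at 10 uM; on this read-out lower numbers stand for less inhibition of growth and higher numbers for more inhibition of growth at the one concentration tested. Compound 1 `Cc1cc(=O)c2c(O)cc(OCc3ccccc3Br)c([C@H]3CCN(C)C[C@H]3O)c2o1` gives 32%, compound 2 `Cc1cc(=O)c2c(O)c(CN3CCC(Cc4ccccc4)CC3)c(O)c([C@H]3CCN(C)C[C@H]3O)c2o1` gives 16%, and compound 3 `Cc1oc2c([C@H]3CCN(C)C[C@H]3O)c(O)cc(O)c2c(=O)c1C(O)c1ccc(Cl)cc1` gives 41%. Compound 3 thus lies within the scatter of compound 1 and clearly higher than compound 2. Compound 4 `Cc1oc2c([C@H]3CCN(C)C[C@H]3O)c(O)cc(O)c2c(=O)c1C(O)c1ccc(F)c(Br)c1` carries 3-bromo-4-fluorophenyl in place of 4-chlorophenyl on a saturated chain carbon bound to an aromatic carbon and an oxygen on a saturated carbon. Within the data shown here, no measured pair shows a change of this kind, so no step beyond the scatter is expected in this assay, in either direction. The estimated step of a number 1 percentage points higher from compound 3 to compound 4 (within the scatter) is expected to stay within the scatter. Compound 4 is estimated at 42%, with an expected range of 28% to 56%.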

Compound 4, percent growth inhibition at one concentration: 72%
Compound 4: the middle estimate sits 30 percentage points below what was measured, outside the stated range (above it).
By their numbers in this assay, from the lowest: compound 2; then compounds 1 and 3 (each within the scatter of the next); then compound 4.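

In this assay, putting 3-bromo-4-fluorophenyl in place of 4-chlorophenyl on the saturated chain carbon gives a number 31 percentage points higher from compound 3 to compound 4 (beyond the scatter). The earlier compounds shown here showed no step at this position; this one shows that growth inhibition here responds strongly to the halogens on the aromatic ring, even though the ring itself stays the same. No measurement at hand accounts for the size of this step. Open, going by these compounds, is whether the bromine or the fluorine carries the gain, as 3-bromophenyl and 4-fluorophenyl would show. Also open, on these data alone, is how an amine or a carboxylic acid on this ring would fare.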